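Dimethoxyphenyl for phenyl on the styryl chain of compound 1

The source may report more compounds than this note shows. Statements on the series, on what has been measured and on what is new or still open speak of the compounds shown alone.

Measured so far:
Compound 1 `COc1ccc([C@H](O)[C@H]2CO[C@@H](c3ccc(OC)c(OC)c3)[C@H](C/C=C/c3ccccc3)C2)cc1OC`: 16100 nM
Compound 2 `COc1ccc([C@H]2OC[C@H]([C@@H](O)c3ccc(OC)c(OC)c3)C[C@@H]2C/C=C/c2ccccc2)cc1OC`: 14800 nM
Compound 3 `COc1ccccc1/C=C/C[C@H]1C[C@@H]([C@@H](O)c2ccccc2)CO[C@@H]1c1ccccc1`: 14700 nM

In a functional assay on HeLa cells (Homo sapiens) for cytotoxicity, read by WST assay, with a stated time of 48 h (on this read-out higher numbers stand for weaker inhibition and lower numbers for stronger inhibition), compound 1 gives 16100 nM, and compound 2 and compound 3 both sit within the scatter of that number; compound 1 has no place apart from them. Among the measured compounds shown here, the one step measured between two compounds differing in a single place, a 1.1-fold lower number from compound 1 to compound 2 (0.04 log units; within the scatter), is a change of configuration only the fact that compounds 1 and 2 differ only in the configuration as drawn and says nothing about the aryl groups. Compound 4 `COc1ccc(/C=C/C[C@@H]2C[C@@H]([C@@H](O)c3ccc(OC)c(OC)c3)CO[C@H]2c2ccc(OC)c(OC)c2)cc1OC` departs from compound 1 by 3,4-dimethoxyphenyl in place of phenyl on a double-bonded chain carbon bound to a double-bonded chain carbon. For the measured compounds named here, no measured step bears on this change, so nothing beyond the scatter is expected; the step is estimated as a 1.1-fold lower number from compound 1 to compound 4 (0.03 log units; within the scatter). Compound 4 is therefore expected to give about 15000 nM, in the range 6000 nM to 40000 nM.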

Compound 4, half-maximal inhibitory concentration: 30600 nM
Compound 4: middle estimate off by 2.0-fold (0.31 log units), on the low side, within the range that was stated.
By their numbers in this assay, from the lowest: compounds 3, 2, 1 and 4 (each within the scatter of the next, the first and the last beyond it).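

In this assay, 3,4-dimethoxyphenyl in place of phenyl on a double-bonded chain carbon bound to a double-bonded chain carbon gives a 1.9-fold higher number from compound 1 to compound 4 (0.28 log units; within the scatter). This position therefore takes the larger aryl group without a step beyond the scatter, which the earlier step, a change of configuration only, could not show. Nothing available accounts for this step.

Going by these compounds, whether an amine or a carboxylic acid on this phenyl would move the number beyond the scatter remains open. So does whether the same exchange would read alike in the configuration of compound 2.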